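Same Cytotoxicity Limit, a Trimmed Amide Side Chain

The source may report more compounds than this note shows. Statements on the series, on what has been measured and on what is new or still open speak of the compounds shown alone.

Three compounds share one core: compound 1 `CC(C)CNC(=O)[C@H](C)NC(=O)[C@@]1(Cc2ccccc2)CCN1C(=O)OCc1ccccc1`, compound 2 `C[C@H](NC(=O)[C@]1(Cc2ccccc2)CCN1C(=O)Oc1cccc2ccccc12)C(N)=O` and compound 3 `CC(C)CNC(=O)[C@H](C)NC(=O)[C@]1(Cc2ccccc2)CCN1C(=O)OCc1ccccc1`. In an ADME assay on HELF cells (Homo sapiens) for cytotoxicity, with a stated time of 3 days (a lower number here means that less compound is tolerated, a higher number that more compound is tolerated), compound 1 gives only a limit of > 100000 nM. In this assay compound 2 likewise gives a limit of > 100000 nM. In this assay compound 3 also reaches only a limit of > 100000 nM. The step that the two limits leave unreadable from compound 1 to compound 3 cannot be sized because the limit of > 100000 nM in this assay, at which 3 of the 3 values shown sit, covers both ends, while the fact that compounds 1 and 3 differ only in the configuration as drawn describes the difference between them. Compound 4 `CC(C)[C@H](NC(=O)[C@]1(Cc2ccccc2)CCN1C(=O)OCc1ccccc1)C(N)=O` carries 1-carbamoyl-2-methylpropyl in place of 1-(isobutylcarbamoyl)ethyl on an amide-type nitrogen. Among the compounds with values here, with every measured value resting at the same limit, no step points in any direction, so compound 4 is expected to show a change within the scatter, a step that the limit leaves unreadable from compound 3 to compound 4. The estimate for compound 4 in this assay is 150000 nM, spanning 50000 nM to 500000 nM.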

Compound 4, half-maximal cytotoxic concentration: 100000 nM
Compound 4: the middle estimate sits 1.5-fold (0.18 log units) above what was measured; measured number inside the range.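

Compound 4 is the only one shown with a plain number in this assay: it gives 100000 nM as a measured value, not a limit. On this amide-type nitrogen, 1-carbamoyl-2-methylpropyl in place of 1-(isobutylcarbamoyl)ethyl gives a number no higher from compound 3 to compound 4 (the limit leaves the size open). As far as these compounds go, the size of that step stays open because compound 3 gives only a limit: the limit of > 100000 nM in this assay, at which 3 of the 4 values shown sit.

Whether the shorter side chain itself moves the number cannot be read. From the compounds shown here alone, what an amine or a carboxylic acid on this nitrogen would give in this assay also stays open.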